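Swapping a Sulfur Link for Oxygen on the Shared Core

This account rests on a few compounds, and the source may have more. Where it says the series, first, only, none or still open, it means among the compounds named here.

Compound 1 `Nc1cc(N)c2nc(-c3ccccc3)c(Oc3ccc(Cl)c(Cl)c3)nc2c1` gives in a functional assay on DU-145 cells (Homo sapiens) for inhibition, read by sulforhodamine B assay, with a stated time of 48 h (a higher number here means that more compound is tolerated, a lower number that less compound is tolerated), a limit of < 100000 nM.
Compound 2 `Nc1cc(N)c2nc(-c3ccccc3)c(NCc3ccc(Cl)c(Cl)c3)nc2c1` gives in this assay 69200 nM.
Compound 3 `Nc1cc(N)c2nc(-c3ccccc3)c(Sc3ccc(F)cc3)nc2c1` gives in this assay a limit of < 100000 nM.

Compound 3 stands only at a limit in this assay, not at a number, and it shares that position with one other compound, as the limit of < 100000 nM in this assay, at which 2 of the 3 values shown sit, records. Compound 4 `Nc1cc(N)c2nc(-c3ccccc3)c(Oc3ccc(F)cc3)nc2c1` has not yet been measured in this assay. It differs from compound 3 in one place: 4-fluorophenoxy in place of (4-fluorophenyl)sulfanyl on an aromatic carbon.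

Going by the values given here, only one measured step is related, and it does not help much: a step that the two limits leave unreadable from compound 1 to compound 3. Both ends of that step are limits, so its size cannot be read. Among the compounds with values here, no measured step replaces a (4-fluorophenyl)sulfanyl with a 4-fluorophenoxy group, so the direction of the change is unknown. Because compound 3 sits at the limit < 100000 nM and compound 1, which also carries a phenoxy link, sits at the limit < 100000 nM, compound 4 is expected to land near the same limit as well, with no readable step that the limit leaves unreadable from compound 3 to compound 4. The value expected for compound 4 in this assay is 70000 nM, within the range 30000 nM to 150000 nM.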

Compound 4, concentration lethal to 50% of the cells: < 100000 nM
Compound 4: no number, only a limit (the forecaster's own chance of this, stated with the estimate: 60%); the middle value is on the limit's open side.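

Compound 4 gives only a limit, < 100000 nM, so neither its step from compound 3 nor its step from compound 1 can be read: the limit of < 100000 nM in this assay, at which 3 of the 4 values shown sit.

Still open, as far as these compounds go, is whether 4-fluorophenoxy and (4-fluorophenyl)sulfanyl differ at all, as compound 1, compound 3 and compound 4 have no exact values.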